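The compounds below may be only part of what the source reports. "The series", "measured", "known", "first", "only" and "open" are said of these compounds alone.

Measured so far in a functional assay on thoracic aorta (Rattus norvegicus, strain Wistar), with a stated time of 15 min; on this read-out lower numbers stand for an effect already at smaller amounts and higher numbers for an effect only at larger amounts of compound:

compound 1 `Cc1ccc(S(=O)(=O)N(C)C(=O)NC(C)c2cc(Br)ccc2OCc2ccccc2)cc1`, 67100 nM
compound 2 `Cc1ccc(S(=O)(=O)N(C)C(=O)NC(C)c2cc(Br)ccc2OC(C)C)cc1`, 34700 nM
compound 3 `CC(NC(=O)NS(=O)(=O)c1ccccc1)c1cc(Br)ccc1OCc1ccccc1`, 130000 nM

Compound 1 and compound 2 share one core and differ in a single place: isopropyl in place of benzyl on an oxygen on an aromatic ring. The step of a 1.9-fold lower number from compound 1 to compound 2 (0.29 log units; within the scatter) stays within the usual scatter, so the two numbers cannot be told apart with confidence. Compound 3 carries a different core; the difference between the two cores is not broken down here. Its value in this assay stands nearest to that of compound 1 and furthest from that of compound 2.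

Compound 4 `CC(C)Oc1ccc(Br)cc1C(C)NC(=O)NS(=O)(=O)c1ccccc1` has not yet been measured. It differs from compound 3 in exactly the way compound 2 differs from compound 1: isopropyl in place of benzyl on an oxygen on an aromatic ring. The place is the same, so this is the same change on another core. Within the data shown here, because the only measured instance of this change, a 1.9-fold lower number from compound 1 to compound 2 (0.29 log units; within the scatter), lay within the scatter, the step from compound 3 to compound 4 is expected to be of similar size, a 1.9-fold lower number from compound 3 to compound 4 (0.27 log units; within the scatter). For compound 4 in this assay the estimate is 70000 nM, with a likely range from 30000 nM to 180000 nM.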

Compound 4, half-maximal effective concentration: 143000 nM
Estimate against measurement, compound 4: 2.0-fold (0.31 log units) below; the range from low to high includes it.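

On the second core, isopropyl in place of benzyl on an oxygen on an aromatic ring again gives a step within the scatter in this assay (a 1.1-fold higher number from compound 3 to compound 4 (0.04 log units; within the scatter)). The two steps cannot be told apart, so the data fit a change that carries over between these two cores, with benzyloxy and isopropoxy giving no readable difference on either: the same change on two cores in this assay, a 1.9-fold lower number (0.29 log units; within the scatter) from compound 1 to compound 2 and a 1.1-fold higher number (0.04 log units; within the scatter) from compound 3 to compound 4, 2.1-fold (0.33 log units) apart, within the scatter of two such steps

This does not show that the change has a real effect of a shared size: with both steps inside the scatter, a small common shift and no shift at all remain equally possible, and two cores say nothing about any other core in the series.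

The compounds shown carry only benzyl and isopropyl on this oxygen, so a free hydroxyl, a methyl or a longer chain there remains open. Equally open, going by these compounds, is what this assay would read for a chlorine or a nitrile in place of the bromine.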